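The compounds below may be only part of what the source reports. "The series", "measured", "known", "first", "only" and "open" are said of these compounds alone.

Measured so far in an ADME assay on Vero cells (Chlorocebus sabaeus) for cytotoxicity, with a stated time of 7 days; on this read-out lower numbers stand for higher toxicity in this test and higher numbers for lower toxicity in this test:

Compound 1 `COc1cccc(CN2C(=O)CN(C(=O)c3cc4cc(OC)ccc4o3)C[C@@H]2CCc2ccccc2)c1`: 4500 nM
Compound 2 `COc1ccc2[nH]c(C(=O)N3CC(=O)N(Cc4ccccc4)[C@@H](COc4ccccc4)C3)cc2c1`: > 10000 nM, a limit of the assay and not a number

For the measured compounds named here, compound 1 is the one with a plain number in this pair. The reading for compound 2, > 10000 nM, is a limit, so compound 2 offers no exact starting point.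

Compound 3 `COc1ccc2[nH]c(C(=O)N3CC(=O)N(Cc4ccccc4)[C@@H](COCc4ccccc4)C3)cc2c1` keeps the shared core of compound 2 and alters one group: benzyl in place of phenyl on an oxygen on a saturated carbon, which turns phenoxymethyl into (benzyloxy)methyl (benzyl in place of phenyl on an oxygen on a saturated carbon). Going by the values given here, no measured pair of compounds isolates this change, so the expectation rests on how small the change is. The expected step, a number no higher from compound 2 to compound 3 (the limit leaves the size open), is estimated to be no larger than the scatter, with no firm direction. A result close to compound 1 at 4500 nM would still be possible for compound 3. Another report of a limit is about as likely as a number. For compound 3 the estimate is 10000 nM, with an expected range from 4500 nM to 22000 nM.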

Compound 3, half-maximal cytotoxic concentration: > 30000 nM
Compound 3 was reported as a limit; the forecaster's own chance of this, stated with the estimate: 55%; middle value at least 3.0-fold (0.47 log units) from the limit.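

In this assay compound 2 and compound 3 both stand as limits of the assay and not as numbers, so no step can be read between them. The compounds shown leave open how far benzyl in place of phenyl on an oxygen on a saturated carbon shifts this read-out, or whether it shifts it at all.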